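The source may hold more compounds than are shown below. What is called first, only, known or untested is meant among the compounds shown, and "the series" means these compounds.

Three compounds built on one shared core have been examined in an ADME assay on HeLa cells (Homo sapiens) for cytotoxicity, read by MTT assay; a lower number here means a stronger inhibitor, a higher number a weaker inhibitor. Compound 1 `N#Cc1c(-c2ccccc2Cl)c(C#N)c(=O)n(/N=C/c2cn(-c3ccccc3)nc2-c2ccccc2)c1N` reaches only the limit of the assay: in this assay compound 1 gives > 200 ug/mL, a limit rather than a number. Compound 2 `Cc1ccc(-c2c(C#N)c(N)n(/N=C/c3cn(-c4ccccc4)nc3-c3ccccc3)c(=O)c2C#N)cc1` likewise stops at the limit, and in this assay compound 2 gives > 200 ug/mL. Compound 3 `N#Cc1c(-c2cccc([N+](=O)[O-])c2)c(C#N)c(=O)n(/N=C/c2cn(-c3ccccc3)nc2-c2ccccc2)c1N` behaves the same way, and in this assay compound 3 gives > 200 ug/mL. Because every one of these values sits at the limit of > 200 ug/mL in this assay, at which 3 of the 3 values shown sit, none of the steps among them can be sized: a step that the two limits leave unreadable from compound 1 to compound 2, a step that the two limits leave unreadable from compound 1 to compound 3 and a step that the two limits leave unreadable from compound 2 to compound 3 are all unreadable, as the aryl group on the core is exchanged without any reading moving off the limit.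

Compound 4 `N#Cc1c(-c2ccc(C(F)(F)F)cc2)c(C#N)c(=O)n(/N=C/c2cn(-c3ccccc3)nc2-c2ccccc2)c1N` has not yet been measured. It differs from compound 2 in one place: trifluoromethyl in place of methyl on an aromatic carbon, the same difference read one bond further out being 4-methylphenyl to 4-(trifluoromethyl)phenyl. Going by the values given here, the steps that bear on this change are the three aryl exchanges above, and all of them show nothing beyond the limit. Compound 4 is therefore expected to give 200 ug/mL in this assay, within a range from 100 ug/mL to 300 ug/mL. The step expected from this is a number no higher from compound 2 to compound 4 (the limit leaves the size open), none beyond the scatter.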

Compound 4, half-maximal inhibitory concentration: > 200 ug/mL
Compound 4: only a limit was reported; the forecaster's own chance of this, stated with the estimate: 80%; the middle value sits exactly at the limit.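

In this assay compound 4 gives > 200 ug/mL, a limit rather than a number, so its steps to compound 1, compound 2 and compound 3 cannot be read: the limit of > 200 ug/mL in this assay, at which 4 of the 4 values shown sit.

The compounds shown leave open whether exchanging the aryl group on the shared core changes the reading at all, with no number yet to compare.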